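The source may report more compounds than this note shows. Statements on the series, on what has been measured and on what is new or still open speak of the compounds shown alone.

Compounds measured:
Compound 1 `Clc1ccc(COc2ccc(/C=C/C(/C=C/c3ccccn3)=N/Oc3ncnc4cc(Cl)ccc34)cc2)cc1` gives 67.4% in a functional assay on SMMC-7721 cells (Homo sapiens) for inhibition, read by MTT assay, with a stated time of 72 h, tested at 1 uM; a lower number here means a weaker effect, a higher number a stronger effect of the compound at the concentration tested.
Compound 2 `Fc1ccccc1COc1ccc(/C=C/C(/C=C/c2ccccn2)=N/Oc2ncnc3cc(Cl)ccc23)cc1` gives 81.1% in this assay.

Among the measured compounds shown here, compound 2 stands highest of the two numbers; the only step is a number 13.7 percentage points higher from compound 1 to compound 2 (beyond the scatter). Compound 3 `Cc1cccc(COc2ccc(/C=C/C(/C=C/c3ccccn3)=N/Oc3ncnc4cc(Cl)ccc34)cc2)c1` is not yet measured. The change is 3-methylphenyl in place of 2-fluorophenyl on a saturated chain carbon bound to an oxygen on an aromatic ring. For the measured compounds named here, no measured step covers this change; the one step compares 4-chlorophenyl and 2-fluorophenyl, not 3-methylphenyl, so no direction can be drawn from it. A step of a number 7.1 percentage points lower from compound 2 to compound 3 (within the scatter) is expected, within the scatter. Compound 3 is estimated at 74%, ranging from 58% to 88%.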

Compound 3, a percentage reported as inhibition, at one concentration (the size of the read-out at that concentration, not a potency): 78.6%
The estimate for compound 3 lay 4.6 percentage points below the measured number; measured number inside the range.
By their numbers in this assay, from the lowest: compound 1; then compounds 3 and 2 (each within the scatter of the next).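

In this assay, 3-methylphenyl on a saturated chain carbon bound to an oxygen on an aromatic ring cannot be told apart from 2-fluorophenyl (a number 2.5 percentage points lower from compound 2 to compound 3 (within the scatter)). Against 4-chlorophenyl, however, it gives a clear gain (a number 11.2 percentage points higher from compound 1 to compound 3 (beyond the scatter)), so among these three compounds a fluorine on this ring is not required to stay above compound 1. No measurement here explains these differences. Open, from the compounds shown here alone, is how an amine or a carboxylic acid on this ring would compare, and whether a longer chain carrying the ring would hold these values.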